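Working notes: sulfonyl aryl change and antiproliferative potency

The compounds below may be only part of what the source reports. "The series", "measured", "known", "first", "only" and "open" are said of these compounds alone.

Measured so far:
compound 1 `CC1CCN(C2CCN(S(=O)(=O)c3ccccc3Br)CC2)CC1` — 3 nM
compound 2 `Cc1cc(C)c(S(=O)(=O)N2CCC(N3CCC(Cc4ccccc4)CC3)CC2)c(C)c1` — 3 nM

In a functional assay on HT-29 cells (Homo sapiens) for antiproliferative activity, read by CellTiter-Glo, with a stated time of 72 h (a lower number here means a stronger inhibitor, a higher number a weaker inhibitor), compound 1 gives 3 nM, and compound 2 gives 3 nM; the two sit level within the scatter, so neither can be set apart from the other. Among the measured compounds shown here, compound 1 therefore stands at the same mark as the only other measured member of the series. The next compound, compound 3 `CC1CCN(C2CCN(S(=O)(=O)c3ccc(Cl)c(Cl)c3)CC2)CC1`, differs from compound 1 in one place: 3,4-dichlorophenyl in place of 2-bromophenyl on a sulfonyl sulfur. For the measured compounds named here, no step of this kind between measured compounds is known, and compound 2 carries a different group on the sulfonyl sulfur altogether, so there is no measured pair to lean on. With both measured compounds at the same level in this assay, the expectation is that a change confined to the halogens on the aryl group moves the value little, probably not beyond the scatter, with a slight loss as the more likely direction if any. The step expected from compound 1 to compound 3 is a 1.3-fold higher number from compound 1 to compound 3 (0.12 log units; within the scatter). Compound 3 is accordingly estimated at 4 nM, with a range from 1.5 nM to 12 nM.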

Compound 3, half-maximal inhibitory concentration: 2.2 nM
The estimate for compound 3 lay 1.8-fold (0.26 log units) above the measured number, and the stated range covers the measured number.
By their numbers in this assay, from the lowest: compounds 3, 1 and 2 (each within the scatter of the next).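

On the sulfonyl sulfur, 3,4-dichlorophenyl in place of 2-bromophenyl gives a 1.4-fold lower number from compound 1 to compound 3 (0.13 log units; within the scatter) in this assay. Among the compounds shown here, this is the only measured step at this position, and it shows that the bromine can give way to two chlorines, placed differently on the phenyl ring, without the value leaving the scatter. Halogen type, halogen count and substitution pattern all change in this one step, so their separate contributions cannot be read from it, and no supporting data bear on the result.

The aryl groups shown carry only halogen or methyl substituents, so it remains open whether the value holds with an unsubstituted phenyl, or with a carboxylic acid or an amine on the ring. Going by these compounds, whether an aryl group is needed on the sulfonyl sulfur at all is also open, for example with cyclohexyl in its place.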